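The source may hold more compounds than are shown below. What is called first, only, known or untested is meant among the compounds shown, and "the series" means these compounds.

Compound 2, `O=C(CN(c1nc(Cl)nc2[nH]cnc12)C1CC1)N[C@@H](CO)C(=O)O`, is the free acid counterpart of compound 1, `O=C(CN(c1nc(Cl)nc2[nH]cnc12)C1CC1)N[C@@H](CO)C(=O)OCc1ccccc1`. In a functional assay on the whole organism (Tail, strain ICR) with Mus musculus as the target, in the tail flick test, with a stated time of 150 min, at a dose of 25 umol/kg by the oral route (a higher number here means a stronger effect of the compound at the dose given, a lower number a weaker effect), compound 1 gives 27.9%, and in this assay compound 2 gives 18.8%. For the measured compounds named here, of the two numbers, that of compound 2 is the smaller, but the only measured step, a number 9.1 percentage points lower from compound 1 to compound 2 (within the scatter), lies within the scatter, so no real separation between the pair is claimed.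

Compound 3, `CC(C)[C@H](NC(=O)CN(c1nc(Cl)nc2[nH]cnc12)C1CC1)C(=O)O`, differs from compound 2 by isopropyl in place of hydroxymethyl on a saturated chain carbon bound to an amide-type nitrogen and a carbonyl carbon. Going by the values given here, no measured step bears on this place: the single recorded step, a number 9.1 percentage points lower from compound 1 to compound 2 (within the scatter), concerns a different part of the molecule and says nothing about the side chain on the amino acid. With nothing to lean on, no shift beyond the scatter is expected in this assay, and the expected step is a number 3.2 percentage points higher from compound 2 to compound 3 (within the scatter). Compound 3 is therefore estimated at 22% in this assay, with a broad range from 5% to 45% reflecting the absence of any comparable change in the series.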

Compound 3, a percentage reported as activity, at one dose (the size of the read-out at that dose, not a potency): 7.86%
Estimate against measurement, compound 3: 14.1 percentage points above; the range from low to high includes it.
By their numbers in this assay, from the lowest: compound 3; then compounds 2 and 1 (each within the scatter of the next).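

In this assay, for the compounds shown here, this saturated chain carbon bound to an amide-type nitrogen and a carbonyl carbon proves sensitive to its substituent: isopropyl in place of hydroxymethyl gives a number 10.9 percentage points lower from compound 2 to compound 3 (beyond the scatter), the only step so far to clear the scatter. The series therefore has one modest signal at this place, whereas the earlier pair gave none at the oxygen next to the carbonyl group. Nothing available on these compounds accounts for the step.

A single pair cannot separate loss of the hydroxyl from gain of the branched carbon chain, and a plain methyl, a longer chain or an amine at this place would bear on that question. From the compounds shown here alone, it also remains open whether a benzyl ester of compound 3 would keep this gap.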